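Fluoro to Chloro on the Amide Aryl Ring

A few compounds are considered here, and "the series" means these few. Any claim that something is new, unique, unknown or untested is made for them only; others in the source may bear on it.

Measured so far:
Compound 1, `CN1C[C@H](C(=O)Nc2ccc(F)c(Cl)c2)[C@@H](c2ccc(/C=C/C(=O)Nc3ccccc3N)cc2)C1`: 34 mL/min/kg
Compound 2, `CN1C[C@H](C(=O)Nc2ccc(Cl)c(Cl)c2)[C@@H](c2ccc(/C=C/C(=O)Nc3ccccc3N)cc2)C1`: 36 mL/min/kg
Compound 3, `CN1C[C@H](C(=O)Nc2ccc(F)cc2F)[C@@H](c2ccc(/C=C/C(=O)Nc3ccccc3N)cc2)C1`: 27 mL/min/kg

All three were run in an in vitro ADME assay on microsomes from liver (Mus musculus) for pharmacokinetics, read by LC-MS, with a stated time of 10 min, tested at 1 uM; a lower number here means slower removal, a higher number faster removal of the compound. Compound 4, `CN1C[C@H](C(=O)Nc2ccc(Cl)cc2F)[C@@H](c2ccc(/C=C/C(=O)Nc3ccccc3N)cc2)C1`, has not yet been measured there.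

Compound 3 differs from compound 1 in the ring attached to the amide nitrogen: 2,4-difluorophenyl in place of 3-chloro-4-fluorophenyl on an amide-type nitrogen. Compound 4 differs from compound 3 by chloro in place of fluoro on an aromatic carbon. The same kind of change has already been seen once, from compound 1 to compound 2: chloro in place of fluoro on an aromatic carbon. The surroundings are not identical, though: in the earlier pair the changed carbon sits ortho to a chloro group, while in the new pair it sits meta to a fluoro group. That earlier step gave a 1.1-fold higher number from compound 1 to compound 2 (0.02 log units; within the scatter), a shift too small to separate from repeat-measurement noise.

On that basis the step from compound 3 to compound 4 is expected to be small, about a 1.1-fold higher number from compound 3 to compound 4 (0.05 log units; within the scatter), because the earlier fluoro-to-chloro step gave a 1.1-fold higher number from compound 1 to compound 2 (0.02 log units; within the scatter). Compound 4 is therefore estimated at 30 mL/min/kg, likely between 20 mL/min/kg and 45 mL/min/kg.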

Compound 4, clearance: 43 mL/min/kg
Beside the measured number, compound 4's estimate is 1.4-fold (0.16 log units) below it; the measured number falls inside the stated range.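

Fluoro-to-chloro replacement has now been seen in two settings in this assay, and the two results cannot be told apart: the same change on two cores in this assay, a 1.1-fold higher number (0.02 log units; within the scatter) from compound 1 to compound 2 and a 1.6-fold higher number (0.20 log units; within the scatter) from compound 3 to compound 4, 1.5-fold (0.18 log units) apart, within the scatter of two such steps. The new step is a 1.6-fold higher number from compound 3 to compound 4 (0.20 log units; within the scatter), and the two swaps of the whole aryl ring give a 1.2-fold higher number from compound 2 to compound 4 (0.08 log units; within the scatter) and a 1.3-fold higher number from compound 1 to compound 4 (0.10 log units; within the scatter), so none of these steps separates from repeat-measurement noise. This suggests the change carries over between these two pairs without a detectable difference, but two pairs from one series do not show that it has no effect or that it would behave the same way on another core.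

The compounds shown leave open how this assay would respond to a group other than fluoro or chloro at this place on the ring, such as a methoxy group, a nitrile or an amine. They also leave open whether a carboxylic acid there would produce a step clearly beyond the scatter.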